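The source may report more compounds than this note shows. Statements on the series, on what has been measured and on what is new or still open speak of the compounds shown alone.

Measured compounds:
Compound 1, `CCCNNC(=O)c1ccc(CNC(=O)c2cc3cc(F)ccc3[nH]2)cc1`: 91.3 nM
Compound 2, `CCCNNC(=O)c1ccc(CNC(=O)c2cc3cc(Cl)ccc3[nH]2)cc1`: 37.7 nM
Compound 3, `CCCNNC(=O)c1ccc(CNC(=O)c2cc3cc(F)ccc3o2)cc1`: 56.5 nM

All three were tested in a functional assay on MV4-11 cells (Homo sapiens) for antiproliferative activity, with a stated time of 48 h; a higher number here means a weaker inhibitor, a lower number a stronger inhibitor. Compound 1 and compound 2 share one core and differ only in one place: chloro in place of fluoro on an aromatic carbon. That change made a 2.4-fold lower number from compound 1 to compound 2 (0.38 log units; beyond the scatter). Compound 3 carries a different core; the difference between the two cores is not broken down here. Its value sits between those of compound 1 and compound 2, within the scatter of each, so no order among the three can be drawn from it.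

Compound 4, `CCCNNC(=O)c1ccc(CNC(=O)c2cc3cc(Cl)ccc3o2)cc1`, is not yet measured. It stands to compound 3 as compound 2 stands to compound 1: chloro in place of fluoro on an aromatic carbon. The place of the change is the same in both pairs, so it is the same change on the second core. Because the first instance gave a 2.4-fold lower number from compound 1 to compound 2 (0.38 log units; beyond the scatter), a step of similar size is expected from compound 3 to compound 4, namely a 2.3-fold lower number from compound 3 to compound 4 (0.35 log units; beyond the scatter). Compound 4 is therefore estimated at 25 nM, with a likely range from 11 nM to 55 nM, resting on a single precedent.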

Compound 4, half-maximal inhibitory concentration: 248 nM
The estimate for compound 4 lay 9.9-fold (1.00 log units) below the measured number; measured number outside the range, above it.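

In this assay, chloro in place of fluoro on an aromatic carbon did not carry over from one core to the other: on the second core it gave a 4.4-fold higher number from compound 3 to compound 4 (0.64 log units; beyond the scatter), opposite in direction to the earlier step, and the two steps clearly differ: the same change on two cores in this assay, a 2.4-fold lower number (0.38 log units; beyond the scatter) from compound 1 to compound 2 and a 4.4-fold higher number (0.64 log units; beyond the scatter) from compound 3 to compound 4, 11-fold (1.03 log units) apart, beyond the scatter of two such steps In this series, then, the outcome of this change depends on the core that carries it, and a step read on the core of compound 1 gives no reliable guide to the core of compound 3. Going by these compounds alone, with only one pair on each core, this does not show which feature of the two cores separates them, nor how general the split is.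

The compounds shown leave open whether other groups at this place, such as bromo, methyl or methoxy, would also separate the two cores. They also leave open whether the split would persist if the propyl chain gave way to a longer chain.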